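Toxicity Limits Around a Shared Core and a Pyridyl Exchange

The source may report more compounds than this note shows. Statements on the series, on what has been measured and on what is new or still open speak of the compounds shown alone.

Compound 1, `Cc1ccc(CCOc2ccc(-c3c(C)nc(C)c([C@H](OC(C)(C)C)C(=O)O)c3N3CCC(C)(C)CC3)cc2)cc1`: in a toxicity assay on MT2 cells (Homo sapiens) for cytotoxicity, read by XTT assay, with a stated time of 4 days (on this read-out lower numbers stand for higher toxicity in this test and higher numbers for lower toxicity in this test), compound 1 gives >= 33500 nM, a limit of the assay rather than a number.
Compound 2, `COc1ccc(CCOc2ccc(-c3c(C)nc(C)c([C@H](OC(C)(C)C)C(=O)O)c3N3CCC(C)(C)CC3)cc2)cc1`: compound 2 gives >= 33500 nM, again a limit.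
Compound 3, `Cc1nc(C)c([C@H](OC(C)(C)C)C(=O)O)c(N2CCC(C)(C)CC2)c1-c1ccc(CCCc2ccc(F)cc2)cc1`: compound 3 gives >= 32000 nM, also a limit.

Compound 1 therefore stands only at a limit in this assay, and the two further values shown are limits as well; two of the three sit at the limit of >= 33500 nM in this assay, at which 2 of the 3 values shown sit, and one at the limit of >= 32000 nM in this assay, at which 1 of the 3 values shown sits. The steps among these compounds are accordingly a step that the two limits leave unreadable from compound 1 to compound 2, a step that the two limits leave unreadable from compound 1 to compound 3 and a step that the two limits leave unreadable from compound 2 to compound 3, none of them readable in size or direction.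

The unmeasured compound 4, `Cc1nc(C)c([C@H](OC(C)(C)C)C(=O)O)c(N2CCC(C)(C)CC2)c1-c1ccc(OCCc2cccnc2)cc1`, differs from compound 1 by pyridin-3-yl in place of 4-methylphenyl on a saturated chain carbon, two bonds along the chain from an oxygen on an aromatic ring. Going by the values given here, no measured step around the shared core bears readably on this exchange, since each of them rests on two limits. The account therefore expects no step beyond the scatter, and the expected step from compound 1 to compound 4 is a number no higher from compound 1 to compound 4 (the limit leaves the size open). For compound 4 the estimated value in this assay is 33500 nM, with a range from 15000 nM to 70000 nM, and it is expected that the assay will most likely again report only a limit.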

Compound 4, half-maximal cytotoxic concentration: >= 25000 nM
Compound 4 was reported as a limit (the forecaster's own chance of this, stated with the estimate: 80%); the middle value lies beyond the limit too.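

In this assay compound 4 gives >= 25000 nM, a limit and not a number. Its steps to compound 1, compound 2 and compound 3 each rest on two limits and cannot be read in size or direction. The compounds shown leave open the concentration at which any of them turns toxic in this test, and whether the pyridin-3-yl exchange shifts it at all.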